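The compounds below may be only part of what the source reports. "The series", "measured", "known", "first", "only" and "open" are said of these compounds alone.

Measured so far in this set:
compound 1, `NC(=O)c1c(NC(=O)c2cccc([N+](=O)[O-])c2)sc2c1CCN(Cc1ccc(Cl)cc1Cl)C2`: 16500 nM
compound 2, `NC(=O)c1c(NC(=O)c2ccccc2Cl)sc2c1CCN(C(=S)Nc1ccccc1F)C2`: 12600 nM
compound 3, `Cc1ccccc1C(=O)Nc1sc2c(c1C(N)=O)CCN(C(=S)Nc1ccccc1Cl)C2`: 11000 nM

All three numbers come from a functional assay on MKN-74 cells (Homo sapiens) for antiproliferative activity, with a stated time of 24 h; on this read-out lower numbers stand for stronger inhibition and higher numbers for weaker inhibition. Compound 3 gives the lowest of the three numbers, but its gap to compound 2 and its gap to compound 1 both lie within the scatter of repeated measurements, so the three compounds cannot be ordered on this read-out and none of them is called the most or least potent. For the measured compounds named here, the whole set sits in a weak range, and no pair of measured compounds differs in only one place, so no single structural step has a measured size attached to it.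

Compound 4, `NC(=O)c1c(NC(=O)c2ccncn2)sc2c1CCN(C(=S)Nc1ccccc1Cl)C2`, is not yet measured. It differs from compound 3 in one place: pyrimidin-4-yl in place of 2-methylphenyl on a carbonyl carbon. Going by the values given here, no measured pair shows this exchange, so there is nothing in the set against which to calibrate the step. With all three measured numbers lying within the scatter of each other, the working expectation for compound 4 is no step beyond the scatter, with a slight lean toward a higher number; the expected step from compound 3 to compound 4 is a 1.3-fold higher number from compound 3 to compound 4 (0.10 log units; within the scatter). On that basis compound 4 is estimated at 14000 nM, with a range from 5000 nM to 40000 nM.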

Compound 4, half-maximal inhibitory concentration: 28400 nM
Beside the measured number, compound 4's estimate is 2.0-fold (0.31 log units) below it, and the stated range covers the measured number.
By their numbers in this assay, from the lowest: compounds 3, 2, 1 and 4 (each within the scatter of the next, the first and the last beyond it).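

For the compounds shown here, the step of a 2.6-fold higher number from compound 3 to compound 4 (0.41 log units; beyond the scatter) in this assay is the first in the set with a measured size, and it shows that the group on this carbonyl carbon can move the read-out beyond the scatter, towards weaker inhibition. The change replaces a ring of carbon only with a ring holding 2 hetero atoms, and it also removes the methyl group, so this single exchange combines two differences and the step cannot be assigned to either one alone. Nothing measured on these compounds bears on why the number rises, so the step stands without an explanation.

Still open, from the compounds shown here alone, is whether the ring nitrogens or the missing methyl group carries the step; a plain phenyl or a pyridinyl group on the same carbonyl carbon, with the rest of compound 3 unchanged, would separate the two. Going by these compounds alone, also open is whether any group here moves the number downward from compound 3, for example an aminophenyl or a carboxyphenyl group, since the one step at this position runs upward and gives no direction for other exchanges.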